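The source may report more compounds than this note shows. Statements on the series, on what has been measured and on what is new or still open speak of the compounds shown alone.

Within the data shown here, in an ADME assay on L1210/0 cells (Mus musculus) for cytotoxicity, with a stated time of 48 h (on this read-out higher numbers stand for weaker inhibition and lower numbers for stronger inhibition), only two compounds have been read so far. Among the measured compounds shown here, compound 1 `C=C(Br)[C@H]1O[C@@H](n2cnc3c(N)ncnc32)[C@@H](O)[C@H]1O` gives 25000 nM, the only true number in this small set. Compound 2 `Nc1ncnc2c1nnn2C[C@H]1CCC[C@H]1CO` reports > 200000 nM, which is a limit of the assay and not a number. Compound 3 `Nc1ncnc2c1ncn2[C@@H]1O[C@H](/C=C/F)[C@H](O)[C@@H]1O` has yet to be tested in this assay. It keeps the core of compound 1 and changes one group, with 2-fluoroethenyl in place of 1-bromoethenyl on a saturated ring carbon, next to the ring oxygen (2-fluoroethenyl in place of 1-bromoethenyl on a saturated ring carbon). For the measured compounds named here, no measured pair of close relatives is available to show how large such a swap might be, so the expectation rests on compound 1 alone, at 25000 nM. Both groups are ethenyl groups at the same place on the ring, and no shift beyond the usual scatter is expected. The expected change, a 1.3-fold lower number from compound 1 to compound 3 (0.10 log units; within the scatter), is therefore small and has no firm direction, although the uncertainty is wide. The estimated value for compound 3 is 20000 nM, with an expected range from 4000 nM to 100000 nM.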

Compound 3, half-maximal inhibitory concentration: > 200000 nM
Compound 3: no number, only a limit (the forecaster's own chance of this, stated with the estimate: 15%); middle value at least 10-fold (1.00 log units) away from the limit.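

In this assay compound 3 gives > 200000 nM, which is a limit of the assay and not a number. Although 2-fluoroethenyl and 1-bromoethenyl have the same heavy-atom count and both sit on the same saturated ring carbon, next to the ring oxygen, the change comes with an at least 8.0-fold higher number from compound 1 to compound 3 (0.90 log units; beyond the scatter), showing that the read-out at this position depends on which of these two groups is present, a sensitivity that compound 1 alone could not reveal. The full size of the step remains unknown, and the top of the measurable range limits what the small set can show: the limit of > 200000 nM in this assay, at which 2 of the 3 values shown sit.

The two groups differ in both the halogen and where it sits on the ethenyl group, and the compounds shown do not separate these two changes. Going by these compounds, a compound carrying 1-fluoroethenyl, 2-bromoethenyl or an unsubstituted ethenyl group on the core of compound 1 would be needed to show which change matters, and whether any other group at this position gives a true number remains open.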